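Acetyl to Carbamoyl: Expected Clearance of Compound 3

This account rests on a few compounds, and the source may have more. Where it says the series, first, only, none or still open, it means among the compounds named here.

Of the compounds shown here, two that share one core have been measured in an ADME assay on microsomes from liver (Mus musculus) for metabolic stability, using NADPH, with a stated time of 60 min; on this read-out lower numbers stand for slow clearance and higher numbers for fast clearance. Compound 1 `CC(=O)c1ccc(NC(=O)Nc2ccc(F)c(C(F)(F)F)c2)cc1` is the more stable of the pair: in this assay compound 1 gives 14 uL/min, the lowest of the two numbers seen. Compound 2 `O=C(Nc1ccc(F)c(C(F)(F)F)c1)Nc1ccccn1` in this assay gives 705 uL/min, a number far higher than that of compound 1 and well beyond the usual scatter. Among the measured compounds shown here, the two differ in more than one place, so the gap cannot be tied to any single change; the values show only that compound 1 is cleared much more slowly.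

Compound 3 `NC(=O)c1ccc(NC(=O)Nc2ccc(F)c(C(F)(F)F)c2)cc1` has not yet been measured in this assay. It differs from compound 1 in one place: amino in place of methyl on a carbonyl carbon. For the measured compounds named here, no measured pair shows this change, so the expectation rests on compound 1 giving 14 uL/min in this assay. The step is expected to be small, a 1.4-fold lower number from compound 1 to compound 3 (0.15 log units; within the scatter), a slight fall or none beyond the scatter. Compound 3 is therefore estimated at 10 uL/min, with a range from 4 uL/min to 35 uL/min.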

Compound 3, intrinsic clearance in a liver preparation (reported as CLH), per the amount of preparation that the assay uses: 22 uL/min
For compound 3 the middle estimate is 2.2-fold (0.34 log units) below the measured one; the range from low to high includes it.
By their numbers in this assay, from the lowest: compounds 1 and 3 (each within the scatter of the next); then compound 2.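

In this assay, among the compounds shown here, this is the first step read at this position: amino in place of methyl on a carbonyl carbon gives a 1.6-fold higher number from compound 1 to compound 3 (0.20 log units; within the scatter). The slow clearance of compound 1 is therefore not tied to the methyl of its acetyl group, since with carbamoyl in that place compound 3 stays within the scatter of compound 1, and this one position takes the change with no reading that can be told apart from no effect on this read-out. Nothing among the data given bears on why the step is this small.

The compounds shown leave open whether the carbonyl itself matters at this position, as a nitrile or a carboxylic acid there would test, and whether a longer chain on the carbonyl carbon, such as ethyl, or an amine carrying a methyl group in place of the plain amino would hold the number as well. They also leave open which part of the difference between compound 1 and compound 2 carries the wide gap in clearance, as those two differ in more than one place.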